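Replacing the 3,4-dichlorophenyl group of compound 2

The source may report more compounds than this note shows. Statements on the series, on what has been measured and on what is new or still open speak of the compounds shown alone.

In a functional assay on MCF7 cells (Homo sapiens) for cytotoxicity, read by MTT assay, with a stated time of 72 h (on this read-out lower numbers stand for stronger inhibition and higher numbers for weaker inhibition), two compounds have numbers so far:

- compound 1 `CNC(=O)c1cc(Oc2ccc(C(=O)/C=C/c3cccc(Br)c3)cc2)ccn1` gives 10400 nM
- compound 2 `CNC(=O)c1cc(Oc2ccc(C(=O)/C=C/c3ccc(Cl)c(Cl)c3)cc2)ccn1` gives 13200 nM

For the measured compounds named here, compound 2 sits at 13200 nM and has only one measured neighbour to be compared with. The comparison shows a 1.3-fold higher number from compound 1 to compound 2 (0.10 log units; within the scatter) and so the two numbers cannot be told apart.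

Compound 3 `CNC(=O)c1cc(Oc2ccc(C(=O)/C=C/c3ccc(Br)cc3)cc2)ccn1` has not yet been measured. It differs from compound 2 in one place, 4-bromophenyl in place of 3,4-dichlorophenyl on a double-bonded chain carbon bound to a double-bonded chain carbon with 4-bromophenyl in place of 3,4-dichlorophenyl on a double-bonded chain carbon bound to a double-bonded chain carbon.

Going by the values given here, only one measured step bears on this change. It also exchanges one substituted phenyl for another at the same place, and a 1.3-fold higher number from compound 1 to compound 2 (0.10 log units; within the scatter) is all it moved the number. Among the compounds with values here, no measured compound carries 4-bromophenyl, so this single step is thin support. Even so, no change beyond the scatter is expected in this assay here. The estimated step is a 1.1-fold lower number from compound 2 to compound 3 (0.04 log units; within the scatter) and it points in neither direction with any confidence. The expected value for compound 3 is 12000 nM (estimated range 5500 nM to 25000 nM).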

Compound 3, half-maximal inhibitory concentration: > 50000 nM
Compound 3 gave a limit, no number; the forecaster's own chance of this, stated with the estimate: 5%; middle value at least 4.1-fold (0.61 log units) away from the limit.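

In this assay compound 3 gives a limit of the assay and not a number: the limit of > 50000 nM in this assay, at which 1 of the 3 values shown sits. The earlier pair suggested that this position took one substituted phenyl as readily as another, since 3-bromophenyl and 3,4-dichlorophenyl could not be told apart, but this result shows that the choice of phenyl group can matter, with an at least 3.7-fold higher number from compound 2 to compound 3 (0.57 log units; beyond the scatter) and an at least 4.8-fold higher number from compound 1 to compound 3 (0.68 log units; beyond the scatter), and a higher number here means weaker inhibition. The second of these steps is the more telling, as 3-bromophenyl and 4-bromophenyl carry the same atoms and differ only in where the bromine sits on the ring, so the place of the halogen counts here and not merely its presence.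

The compounds shown cannot tell whether the loss belongs to bromine in particular or to any lone group placed as in 4-bromophenyl, a question on which 4-chlorophenyl, 4-methoxyphenyl or plain phenyl would bear. Going by these compounds, the full size of both steps also stays open, as each gives only a lower bound.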